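Aryl-to-dioxolanylmethyl exchange on the ring nitrogen: paw edema

The source may hold more compounds than are shown below. What is called first, only, known or untested is meant among the compounds shown, and "the series" means these compounds.

Measured so far:
compound 1 `Clc1ccccc1-n1cc(CSc2nc3ccccc3s2)nn1`: 78.1%
compound 2 `Clc1ccc(-n2cc(CSc3nc4ccccc4s3)nn2)cc1`: 43.4%
compound 3 `Brc1ccc(-n2cc(CSc3nc4ccccc4s3)nn2)cc1`: 59.2%

In a functional assay on the whole organism (strain Albino Wistar) for inhibition, with Rattus norvegicus as the target, read by paw edema, with stated times of 1 h and 5 h, at a dose of 10 mg/kg by the oral route (a higher number here means more inhibition at the dose given (going by the name of the read-out), a lower number less inhibition), compound 1 holds the highest of the three numbers. Compound 3 is nearest, with a number 18.9 percentage points lower from compound 1 to compound 3 (beyond the scatter); compound 2 is furthest, with a number 34.7 percentage points lower from compound 1 to compound 2 (beyond the scatter). Between the two, a number 15.8 percentage points higher from compound 2 to compound 3 (beyond the scatter).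

Compound 4 `CC1(C)OCC(Cn2cc(CSc3nc4ccccc4s3)nn2)O1` is not yet measured. The change from compound 1 is (2,2-dimethyl-1,3-dioxolan-4-yl)methyl in place of 2-chlorophenyl on an aromatic nitrogen. Going by the values given here, none of the measured steps bears directly on this: each keeps an aromatic ring on the ring nitrogen and only moves or exchanges a halogen, yet both departures from compound 1 lowered the number beyond the scatter. A step of a different kind, removing the ring altogether, is therefore expected to cost at least as much, and for compound 4 a drop is expected, a number 33.1 percentage points lower from compound 1 to compound 4 (beyond the scatter). Compound 4 is estimated at 45%, with a range from 25% to 68%.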

Compound 4, a percentage reported as inhibition, in the whole organism at one dose (the size of the read-out at that dose, not a potency): 49.1%
Beside the measured number, compound 4's estimate is 4.1 percentage points below it; the measured number falls inside the stated range.
By their numbers in this assay, from the lowest: compounds 2 and 4 (each within the scatter of the next); then compound 3; then compound 1.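

In this assay an aryl group on the ring nitrogen proves not to be needed for inhibition: with (2,2-dimethyl-1,3-dioxolan-4-yl)methyl at this position there is a number 29 percentage points lower from compound 1 to compound 4 (beyond the scatter) and a number 10.1 percentage points lower from compound 3 to compound 4 (beyond the scatter) but only a number 5.7 percentage points higher from compound 2 to compound 4 (within the scatter). This non-aromatic ring therefore cannot be told apart from 4-chlorophenyl, while it stays short of 2-chlorophenyl and 4-bromophenyl. No evidence at hand accounts for these differences.

Still open, on these data alone, is how a 2-bromophenyl group or a plain hexyl chain on the ring nitrogen would read. Also open, as far as these compounds go, is whether the free diol, without the dioxolane ring, would hold the inhibition of compound 4.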